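A few compounds are considered here, and "the series" means these few. Any claim that something is new, unique, unknown or untested is made for them only; others in the source may bear on it.

Among the compounds with values here, compound 3, `Cc1ncnc2c1c(-c1ccsc1)cn2[C@@H]1O[C@H](CO)[C@@H](O)[C@H]1O`, is one of three compounds measured in a functional assay on CCRF-CEM cells (Homo sapiens), read by MTT assay, with a stated time of 72 h (on this read-out higher numbers stand for weaker inhibition and lower numbers for stronger inhibition), where compound 3 gives 11200 nM. This is the second highest number among the three: compound 2, `Cc1ncnc2c1c(-c1cc3ccccc3o1)cn2[C@@H]1O[C@H](CO)[C@@H](O)[C@H]1O`, gives 17300 nM, and compound 1, `COc1ncnc2c1c(I)cn2[C@@H]1O[C@H](CO)[C@@H](O)[C@H]1O`, gives 1150 nM. Within the data shown here, the single step among them, a 1.5-fold lower number from compound 2 to compound 3 (0.19 log units; within the scatter), swaps one aromatic group for another and stays within the scatter.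

The step to compound 4, `Cc1ncnc2c1c(I)cn2[C@@H]1O[C@H](CO)[C@@H](O)[C@H]1O`, is iodo in place of thiophen-3-yl on an aromatic carbon. Among the measured compounds shown here, no measured step matches this change, so the only guide is compound 1, which carries the iodo group together with a methoxy group in place of the methyl group and gives 1150 nM. Compared with compound 3 this is a much lower number, but two groups differ between them, and the two changes cannot be separated from each other. The expectation is still that compound 4 comes closer to compound 1 than to compound 3, and the step of a 5.6-fold lower number from compound 3 to compound 4 (0.75 log units; beyond the scatter) is therefore expected to be a lower number, beyond the scatter. The estimate for compound 4 in this assay is 2000 nM, within 500 nM to 8000 nM.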

Compound 4, half-maximal inhibitory concentration: 5480 nM
Compound 4: middle estimate off by 2.7-fold (0.44 log units), on the low side, within the range that was stated.
By their numbers in this assay, from the lowest: compound 1; then compound 4; then compounds 3 and 2 (each within the scatter of the next).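

In this assay, iodo on this aromatic carbon gives a lower number than either aromatic ring, with a 2.0-fold lower number from compound 3 to compound 4 (0.31 log units; beyond the scatter) for thiophen-3-yl and a 3.2-fold lower number from compound 2 to compound 4 (0.50 log units; beyond the scatter) for 1-benzofuran-2-yl, both modest but beyond the scatter. Compound 4 also separates the two differences that compound 1 and compound 3 carried together: with iodo held in place, methyl instead of methoxy gives a 4.8-fold higher number from compound 1 to compound 4 (0.68 log units; beyond the scatter), so the change at the other aromatic carbon alone moves the number beyond the scatter. No measurement shown here offers an explanation for either step.

The compounds shown leave open whether methoxy in place of methyl would also lower the number with thiophen-3-yl or 1-benzofuran-2-yl present. They also leave open what an amine or a longer chain would give on either carbon.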